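The compounds below may be only part of what the source reports. "The series", "measured", "known", "first", "only" and "open" are said of these compounds alone.

Measured compounds:
Compound 1, `Cc1cnc(Nc2ccc(S(C)(=O)=O)cc2)nc1Nc1nc2ccccc2s1` — in a functional assay on HCT-116 cells (Homo sapiens) for antiproliferative activity, read by MTT assay, with a stated time of 48 h (on this read-out higher numbers stand for weaker inhibition and lower numbers for stronger inhibition), compound 1 gives 760 nM.
Compound 2, `Cc1cnc(Nc2ccc([N+](=O)[O-])cc2)nc1Nc1nc2ccccc2s1` — in this assay compound 2 gives 6330 nM.
Compound 3, `Cc1cnc(Nc2ccc(S(N)(=O)=O)cc2)nc1Nc1nc2ccccc2s1` — in this assay compound 3 gives 1660 nM.

Compound 2 stands highest of the three numbers in this assay. Its nearest neighbour is compound 3, reached by a 3.8-fold lower number from compound 2 to compound 3 (0.58 log units; beyond the scatter), and its furthest is compound 1, from which compound 2 is separated by an 8.3-fold higher number from compound 1 to compound 2 (0.92 log units; beyond the scatter). Both measured steps therefore show that the nitro-bearing compound 2 sits above its two partners, and that exchanging the nitro group for another substituent has so far lowered the number.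

Compound 4, `COc1cccc(Nc2ncc(C)c(Nc3nc4ccccc4s3)n2)c1`, has not yet been measured. It differs from compound 2 in one place: 3-methoxyphenyl in place of 4-nitrophenyl on a nitrogen on an aromatic ring. The two steps that bear on this change are those that remove the nitro group, namely an 8.3-fold higher number from compound 1 to compound 2 (0.92 log units; beyond the scatter) read in reverse and a 3.8-fold lower number from compound 2 to compound 3 (0.58 log units; beyond the scatter). Neither involves a methoxy group, and the replacement in compound 4 also changes where the substituent sits on the ring, so the comparison is indirect. Among the measured compounds shown here, still, a modest step downward is expected, though smaller than the two measured ones, since the new group has no closer precedent. The estimate for compound 4 is 2000 nM, in the range 600 nM to 7000 nM, which corresponds to an expected step of a 3.2-fold lower number from compound 2 to compound 4 (0.50 log units; beyond the scatter).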

Compound 4, half-maximal inhibitory concentration: > 50000 nM
Compound 4: a limit, no number; the forecaster's own chance of this, stated with the estimate: 5%; middle value at least 25-fold (1.39 log units) from the limit.
By their numbers in this assay, from the lowest: compound 1; then compound 3; then compound 2. At a limit, above all of these: compound 4.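

Compound 4 stands at a limit and not at a number: the limit of > 50000 nM in this assay, at which 1 of the 4 values shown sits. Among the compounds shown here, this gives the first step at this position that runs upward on leaving the nitro group, an at least 7.8-fold higher number from compound 2 to compound 4 (0.89 log units; beyond the scatter), whereas the earlier replacement of nitro went the other way, a 3.8-fold lower number from compound 2 to compound 3 (0.58 log units; beyond the scatter). Taking away the 4-nitrophenyl group therefore does not by itself lower the number in this assay: compound 1 and compound 3 both sit below compound 2, compound 4 goes against that pattern, and what enters on the nitrogen matters at least as much as what leaves.

The compounds shown do not separate the change of group from the change of its place on the ring, since 3-methoxyphenyl differs from 4-nitrophenyl in both at once. They also leave open how a plain phenyl, or a phenyl ring carrying an amine or a carboxylic acid, would read at this nitrogen, and so whether the sulfonyl-bearing rings of compound 1 and compound 3 are exceptions or the general case.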